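The source may hold more compounds than are shown below. What is called first, only, known or untested is meant among the compounds shown, and "the series" means these compounds.

Measured compounds:
- compound 1, `CC1CCN(c2c(S(=O)(=O)c3cc(Cl)cc(Cl)c3)cnc3ccc(F)cc23)CC1`, 69%
- compound 2, `Cc1ccc2ncc(S(=O)(=O)c3cc(Cl)cc(Cl)c3)c(N3CCC(C)CC3)c2c1`, 75%

In an assay on isolated protein for displacement of a labelled ligand from metabotropic glutamate receptor 5 (Homo sapiens), with a stated time of 60 min, tested at 1 uM (a lower number here means less inhibition, a higher number more inhibition at the concentration tested (going by the name of the read-out)), compound 2 gives 75%, and compound 1 gives 69%. Among the measured compounds shown here, the one measured step, a number 6 percentage points higher from compound 1 to compound 2 (within the scatter), is within the scatter, so the two compounds cannot be told apart on these numbers.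

Compound 3, `Cc1ccc2ncc(S(=O)(=O)c3ccc(C)c(Cl)c3)c(N3CCC(C)CC3)c2c1`, differs from compound 2 in one place: 3-chloro-4-methylphenyl in place of 3,5-dichlorophenyl on a sulfonyl sulfur. For the measured compounds named here, no measured step touches the group on the sulfonyl sulfur; the only step known, a number 6 percentage points higher from compound 1 to compound 2 (within the scatter), concerns a change elsewhere on the shared core and was itself within the scatter. There is therefore no measured basis for expecting a shift beyond the scatter in this assay, and the expectation is a step of about a number 10 percentage points lower from compound 2 to compound 3 (within the scatter), with wide uncertainty. Compound 3 is estimated at 65%, in a range from 45% to 82%.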

Compound 3, a percentage reported as inhibition, at one concentration (the size of the read-out at that concentration, not a potency): 91%
Compound 3: the middle estimate sits 26 percentage points below what was measured, outside the stated range (above it).
By their numbers in this assay, from the lowest: compounds 1 and 2 (each within the scatter of the next); then compound 3.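

In this assay, the group on the sulfonyl sulfur is the first place shown where a change clearly registers: 3-chloro-4-methylphenyl in place of 3,5-dichlorophenyl gives a number 16 percentage points higher from compound 2 to compound 3 (beyond the scatter), with the rest of the molecule unchanged. This single swap alters two things at once, since the ring loses one chlorine and gains a methyl, so the step belongs to the pair of groups and not to either alteration alone. No measurement shown here accounts for the rise.

On these data alone, it remains open whether 3-chlorophenyl or 4-methylphenyl on the sulfonyl sulfur would give a similar reading, which would help separate the two alterations. Also open, as far as these compounds go, is how this assay would respond to a methoxy group or a nitrile on that ring.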